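Branched and cyclic acyl groups on a shared core

This account rests on a few compounds, and the source may have more. Where it says the series, first, only, none or still open, it means among the compounds named here.

Compound 2 `CC(C)C(=O)N1CC2CC(C1)N2` gives 71% in an assay on SH-EP1 cells for agonist activity at Neuronal acetylcholine receptor; alpha4/beta2 (Homo sapiens), read by FLIPR and calcium flux (a lower number here means a smaller maximal response, a higher number a larger maximal response), the lowest of the three measured values. Compound 1 `CCC(=O)N1CC2CC(C1)N2` gives 110% and compound 3 `O=C(C1CC=CC1)N1CC2CC(C1)N2` gives 95%. Among the compounds with values here, the one measured step that bears on the next change is a number 39 percentage points lower from compound 1 to compound 2 (beyond the scatter), a large drop on gaining a branch. Compound 4 `C[C@@H]1C[C@H]1C(=O)N1CC2CC(C1)N2` differs from compound 2 by 2-methylcyclopropyl in place of isopropyl on a carbonyl carbon. The branch at the carbonyl-bound carbon is kept, but it is now closed into a ring, and ring-bearing compound 3 stands well above compound 2. Given that compound 3 gives 95%, compound 4 is expected to show a modest rise, a number 14 percentage points higher from compound 2 to compound 4 (beyond the scatter). Compound 4 is therefore estimated at 85%, in a range from 60% to 110%.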

Compound 4, largest response reached (Emax), in percent of the reference or control that the assay uses: 110%
Compound 4: middle estimate off by 25 percentage points, on the low side, and the stated range covers the measured number.
By their numbers in this assay, from the lowest: compound 2; then compound 3; then compounds 1 and 4 (each within the scatter of the next).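

In this assay, the drop seen with isopropyl on this carbonyl carbon does not hold for every branched group: 2-methylcyclopropyl in its place brings a clear recovery (as a number 39 percentage points higher from compound 2 to compound 4 (beyond the scatter)). Set against ethyl, the same group leaves the maximal response unmoved (with no change at the digits printed from compound 1 to compound 4 (within the scatter)), so a ring with 2 defined stereocentres is accepted at this place. Nothing measured here accounts for this recovery. Going by these compounds, it remains open whether the other stereoisomers of 2-methylcyclopropyl behave alike, and whether an unsubstituted cyclopropyl or a tert-butyl group on the same carbonyl carbon follows compound 4 or compound 2.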